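This account rests on a few compounds, and the source may have more. Where it says the series, first, only, none or still open, it means among the compounds named here.

Compound 1 `Cc1n[nH]c(-c2ccccc2NCC2=NCCN2)n1` was examined in a functional assay with Alpha-1B adrenergic receptor (Homo sapiens) as the target, read by calcium flux; a lower number here means a smaller maximal response, a higher number a larger maximal response. In this assay compound 1 gives 0%, which amounts to no detectable response at all. Compound 2 `CCn1cccc1-c1ccccc1NCC1=NCCN1` gives 0% in this assay, and these two values sit level at the digits shown, within the usual scatter of each other, so no order can be read between them. Compound 3 `c1ccc(-c2nc[nH]n2)c(NCC2=NCCN2)c1` has not been measured. It differs from compound 1 by a single change, (1H-1,2,4-triazol-3-yl in place of 3-methyl-1H-1,2,4-triazol-5-yl on an aromatic carbon), so the only thing lost is the methyl on the five-membered ring. Among the measured compounds shown here, no comparable step between measured compounds is available for guidance. Because in this assay compound 1 gives 0%, the expectation is that compound 3 likewise produces no response. The step of no change at the digits printed from compound 1 to compound 3 (within the scatter) is expected to be none beyond the scatter. Compound 3 is expected to give 0%, within a range from 0% to 10%.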

Compound 3, largest response reached (reported as maximal response), in percent of the reference or control that the assay uses: 100%
Compound 3: the middle estimate sits 100 percentage points below what was measured; measured number outside the range, above it.
By their numbers in this assay, from the lowest: compounds 1 and 2 (each within the scatter of the next); then compound 3.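

In this assay, replacing 3-methyl-1H-1,2,4-triazol-5-yl with 1H-1,2,4-triazol-3-yl gives a number 100 percentage points higher from compound 1 to compound 3 (beyond the scatter). The earlier compounds shown here showed only an absence of response, whereas this pair shows that the shared core can give a response and that a single methyl on the five-membered ring separates the two outcomes. The two groups have the same hydrogen-bond donor and acceptor counts and differ by one carbon, but no available evidence accounts for the jump.

This is a single pair, so it cannot show whether the loss of response is specific to methyl or would follow from any group at that ring carbon. An ethyl group, a chlorine atom or an amine there could separate those possibilities, and the response of each remains an open question.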